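Hexyl in place of phenylpropyl on the shared core

The source may hold more compounds than are shown below. What is called first, only, known or untested is meant among the compounds shown, and "the series" means these compounds.

Within the data shown here, compound 3 `NS(=O)(=O)OC[C@@H]1C[C@@H](n2nnc3c(NCCCc4ccccc4)ncnc32)C[C@@H]1O` gives the highest number of the three measured members in an assay on a protein complex for inhibition of NEDD8 activating enzyme (Homo sapiens), read by HTRF, with a stated time of 2 h, in the presence of a further agent that is not named here (on this read-out lower numbers stand for stronger inhibition and higher numbers for weaker inhibition), at 149 nM. Compound 1 `NS(=O)(=O)OC[C@@H]1C[C@@H](n2nnc3c(NCc4ccco4)ncnc32)C[C@@H]1O` gives 30.6 nM and compound 2 `NS(=O)(=O)OC[C@@H]1C[C@@H](n2nnc3c(NCc4cccs4)ncnc32)C[C@@H]1O` gives 15.9 nM; the step of a 1.9-fold lower number from compound 1 to compound 2 (0.28 log units; within the scatter) lies within the scatter, whereas a 4.9-fold higher number from compound 1 to compound 3 (0.69 log units; beyond the scatter) and a 9.4-fold higher number from compound 2 to compound 3 (0.97 log units; beyond the scatter) show the phenethyl chain raising the number. Compound 4 `CCCCCCNc1ncnc2c1nnn2[C@@H]1C[C@@H](COS(N)(=O)=O)[C@@H](O)C1` differs from compound 3 by propyl in place of phenyl on a saturated chain carbon, three bonds along the chain from a nitrogen on an aromatic ring. Among the measured compounds shown here, no measured step removes an aromatic ring altogether, so the direction is open; the only guidance is that compound 3 already sits above compounds 1 and 2. The expected step of a 2.0-fold higher number from compound 3 to compound 4 (0.30 log units; within the scatter) is therefore small to moderate, toward a higher number. Compound 4 is estimated at 300 nM in this assay, with a range from 100 nM to 1000 nM.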

Compound 4, half-maximal inhibitory concentration: 21.1 nM
Estimate against measurement, compound 4: 14-fold (1.15 log units) above, outside the stated range (below it).
By their numbers in this assay, from the lowest: compounds 2, 4 and 1 (each within the scatter of the next); then compound 3.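

Loss of the phenyl ring is tolerated at this position: hexyl in place of 3-phenylpropyl gives a 7.1-fold lower number from compound 3 to compound 4 (0.85 log units; beyond the scatter), so in this assay an aromatic ring on this chain is not required. Compound 4 also stands level with the furan-2-yl and thiophen-2-yl members, with a 1.3-fold higher number from compound 2 to compound 4 (0.12 log units; within the scatter) and a 1.5-fold lower number from compound 1 to compound 4 (0.16 log units; within the scatter). Nothing available accounts for the step from phenyl to propyl.

Open, as far as these compounds go, is how chain length alone acts, since only hexyl represents the purely saturated chains here. Also open, from the compounds shown here alone, is whether a longer chain such as octyl, or an amine or a carboxylic acid carried on the hexyl chain, would keep this number.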